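A Methyl Added to the Amine of an Allene

The source may hold more compounds than are shown below. What is called first, only, known or untested is meant among the compounds shown, and "the series" means these compounds.

Compound 1 `C=C=C(Cc1ccccc1)CN(C)C`: 72 umol/kg
Compound 2 `C=C=C(CN)Cc1ccccc1`: a limit, > 26 umol/kg
Compound 3 `C=C=C(CN)Cc1ccc(Cl)cc1`: 18 umol/kg

All three compounds share the same allene core and are compared in an assay on forebrain for inhibition of Monoamine oxidase (Mus musculus); a lower number here means that less compound is needed, a higher number that more compound is needed for the effect. Compound 1 gives 72 umol/kg. For compound 2 the assay reports only a limit, > 26 umol/kg, so where its true number lies is not known. Compound 3 gives 18 umol/kg.

The step from compound 1 to compound 2 is a step that the limit leaves unreadable from compound 1 to compound 2; because of the limit of > 26 umol/kg in this assay, at which 1 of the 3 values shown sits, its size cannot be read. The step from compound 2 to compound 3 is an at least 1.4-fold lower number from compound 2 to compound 3 (0.15 log units; that floor lies within the scatter), which concerns the ring rather than the amine and so says little about what follows.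

Compound 4 `C=C=C(CNC)Cc1ccccc1` is not yet measured. It differs from compound 2 by methyl in place of hydrogen on an amine nitrogen, which places it halfway between the bare amine of compound 2 and the dimethylamino of compound 1. Going by the values given here, the only step that touches the amine is unreadable, so the expectation can rest only loosely on compound 1 with its 72 umol/kg. Compound 2 adds only a limit, > 26 umol/kg. The step is expected to be a step that the limit leaves unreadable from compound 2 to compound 4. Compound 4 is therefore estimated at 45 umol/kg, within a range from 20 umol/kg to 120 umol/kg.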

Compound 4, dose for half-maximal effect: > 38 umol/kg
Compound 4 was reported as a limit; the forecaster's own chance of this, stated with the estimate: 30%; the middle value lies beyond the limit too.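

In this assay compound 4 gives only a limit, > 38 umol/kg. Compound 2 also gives only a limit, > 26 umol/kg. No new step can be read, either from compound 2 to compound 4 or from compound 1 to compound 4. The compounds shown leave open whether methyl in place of hydrogen on an amine nitrogen moves the number in either direction, and by how much.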